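Replacing the oxazole amide with a halogenated phenyl amide

This account rests on a few compounds, and the source may have more. Where it says the series, first, only, none or still open, it means among the compounds named here.

Compound 3 `O=C(Nc1ccc(Cl)c(-c2nnc3c(Cl)cccn23)c1)c1ccon1` carries a 1,2-oxazol-3-yl group on the carbonyl carbon of the shared core. In a functional assay on T47D cells (Homo sapiens) for antiproliferative activity, read by MTT assay, with a stated time of 72 h (a lower number here means a stronger inhibitor, a higher number a weaker inhibitor), compound 3 gives only a limit of the assay, > 100000 nM. Compound 1 `O=C(Nc1ccc(Cl)c(-c2nnc3c(Cl)cccn23)c1)c1cccc(Cl)c1`, which carries 3-chlorophenyl at that position, gives 30200 nM in this assay. Compound 2 `Cc1cc(Cl)ccc1C(=O)Nc1ccc(Cl)c(-c2nnc3c(Cl)cccn23)c1`, with 4-chloro-2-methylphenyl, also reaches only a limit of the assay, > 100000 nM. Compound 3 therefore stands at the limit (the limit of > 100000 nM in this assay, at which 2 of the 3 values shown sit), alongside compound 2, and no number separates it from compound 2; the step that the two limits leave unreadable from compound 2 to compound 3 is unreadable.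

Compound 4 `O=C(Nc1ccc(Cl)c(-c2nnc3c(Cl)cccn23)c1)c1c(F)cccc1Cl` differs from compound 3 by one change: 2-chloro-6-fluorophenyl in place of 1,2-oxazol-3-yl on a carbonyl carbon. For the measured compounds named here, two measured steps bear on it. The step of an at least 3.3-fold higher number from compound 1 to compound 3 (0.51 log units; beyond the scatter) shows that putting the five-membered ring in place of a chlorinated phenyl lost activity, so going back to a halogenated phenyl could recover some of it. Yet the step of an at least 3.3-fold higher number from compound 1 to compound 2 (0.51 log units; beyond the scatter), where a differently substituted chlorophenyl entered, shows that not every halogenated phenyl reaches the level of compound 1. The expected outcome for compound 4 is a step of about an at least 1.6-fold lower number from compound 3 to compound 4 (0.22 log units; that floor lies within the scatter) in this assay, toward a lower number but uncertain. Compound 4 is estimated at 60000 nM, within a range of 20000 nM to 200000 nM, with a fair chance that only a limit is reported.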

Compound 4, half-maximal inhibitory concentration: > 100000 nM
Compound 4: a limit, no number; the forecaster's own chance of this, stated with the estimate: 55%; at least 1.6-fold (0.22 log units) between middle value and limit.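

In this assay, the change to 2-chloro-6-fluorophenyl on the carbonyl carbon gives an at least 3.3-fold higher number from compound 1 to compound 4 (0.51 log units; beyond the scatter). With compound 2, this makes a second halogenated phenyl that does not match the 3-chlorophenyl of compound 1, so among the groups shown, only compound 1 gives a number rather than a limit of the assay: the limit of > 100000 nM in this assay, at which 3 of the 4 values shown sit.

The steps among compound 2, compound 3 and compound 4 cannot be read, so 4-chloro-2-methylphenyl, 1,2-oxazol-3-yl and 2-chloro-6-fluorophenyl cannot be ranked against one another.

Going by these compounds, it remains open whether an unsubstituted phenyl or a 3-bromophenyl on the carbonyl carbon would stay near compound 1 or fall to the same limit. On these data alone, it also remains open whether a saturated amine such as piperidine in place of the aromatic ring would give a measurable number.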